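The source may hold more compounds than are shown below. What is called first, only, known or untested is meant among the compounds shown, and "the series" means these compounds.

Measured compounds

Compound 1, `CC(=O)NC1CCCN(S(=O)(=O)c2ccc(F)cc2)C1`: in a functional assay on the whole organism with Mus musculus as the target, with a stated time of 30 min (a lower number here means that less compound is needed, a higher number that more compound is needed for the effect), compound 1 gives 1 mg/kg.
Compound 2, `CCC(=O)NC1CCCN(S(=O)(=O)c2ccc(F)cc2)C1`: in this assay compound 2 gives 1 mg/kg.
Compound 3, `CC(=O)N1CCN(S(=O)(=O)c2ccc(F)cc2)CC1=O`: in this assay compound 3 gives 0.3 mg/kg.

Compounds 1 and 2 share a core and differ in one place only: methyl in place of hydrogen on a saturated chain carbon bound to a carbonyl carbon. The step this change made is no change at the digits printed from compound 1 to compound 2 (within the scatter), so within this pair the added methyl left the minimum effective dose where it was.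

Compound 3 carries a different core; how its core differs from that of compound 1 is not broken down here. In this assay compound 3 stands lowest of the three measured numbers, and its gap to both compound 1 and compound 2 lies beyond the usual scatter of repeated measurements.

Compound 4, `CCC(=O)N1CCN(S(=O)(=O)c2ccc(F)cc2)CC1=O`, is not yet measured. It is related to compound 3 by methyl in place of hydrogen on a saturated chain carbon bound to a carbonyl carbon. The place reads the same as in the change from compound 1 to compound 2, so this is the same change made on the other core.

Expectation: because the step of no change at the digits printed from compound 1 to compound 2 (within the scatter) showed no change within the scatter, the step from compound 3 to compound 4 is expected to be of about the same size, no change at the digits printed from compound 3 to compound 4 (within the scatter). Compound 4 is therefore estimated to give 0.3 mg/kg in this assay, with a range from 0.15 mg/kg to 0.7 mg/kg covering the ordinary spread of repeated measurements. This rests on one prior instance of the change only.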

Compound 4, minimum effective dose: 0.3 mg/kg
Compound 4: middle estimate and measured number agree at the digits printed; measured number inside the range.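

On the core of compound 3, methyl in place of hydrogen on a saturated chain carbon bound to a carbonyl carbon, which turns acetyl into propanoyl, gives in this assay no change at the digits printed from compound 3 to compound 4 (within the scatter) and leaves the minimum effective dose where it stood. Set beside the earlier step on the core of compound 1, the change carries over between these two cores with no difference in the size of the step: the same change on two cores in this assay, no change at the digits printed (within the scatter) from compound 1 to compound 2 and no change at the digits printed (within the scatter) from compound 3 to compound 4, 1.0-fold (0.00 log units) apart, within the scatter of two such steps. This supports treating acetyl and propanoyl as interchangeable on these two cores in this whole-animal read-out, but it does not show that the change would be equally silent on any other core, and two flat steps cannot show whether the two cores would also respond alike to a change that does move the dose.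

As far as these compounds go, how a longer chain such as butanoyl, or an amine or a carboxylic acid carried on the acyl chain, would read on either core remains open. Also open, from the compounds shown here alone, is whether the two cores would stay in step if the fluorine on the aryl sulfonyl part gave way to chlorine or a methoxy group.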